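The compounds below may be only part of what the source reports. "The series", "measured", "known", "first", "only" and "open" are said of these compounds alone.

Working notes on the series. Three members share one core and differ only in the group carried on a saturated chain carbon bound to an amine nitrogen. Compound 1 `C/C(CN)=C(\F)CN(C[C@H]1Cc2ccccc2CN1)[C@H]1CCCc2cccnc21` gives 28 nM in a functional assay on CCRF-CEM cells for antagonist activity at C-X-C chemokine receptor type 4 (Homo sapiens), read by calcium flux, with stated times of 25 min and 90 s; a higher number here means a weaker inhibitor, a lower number a stronger inhibitor. Compound 2 `NC[C@H]1CC[C@H](CN(C[C@H]2Cc3ccccc3CN2)[C@H]2CCCc3cccnc32)CC1` gives 340 nM in this assay, and compound 3 `C/C(CN(C[C@H]1Cc2ccccc2CN1)[C@H]1CCCc2cccnc21)=C(\F)CN` gives 80 nM in this assay. Compound 3 thus holds the second highest number of the three: the step of a 2.9-fold higher number from compound 1 to compound 3 (0.46 log units; beyond the scatter) lies beyond the scatter, as does the step of a 4.3-fold lower number from compound 2 to compound 3 (0.63 log units; beyond the scatter).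

Compound 4 `C/C(=C/CN)CN(C[C@H]1Cc2ccccc2CN1)[C@H]1CCCc2cccnc21` has not been measured. It differs from compound 3 in this way: a group of 5 heavy atoms (4 carbon, 1 nitrogen; no ring) in place of a group of 6 heavy atoms (4 carbon, 1 nitrogen, 1 fluorine; no ring), on a saturated chain carbon bound to an amine nitrogen. The fluorine of compound 3 is gone, the chain otherwise keeping its length and its single double bond.

Which measured steps bear on this? The step of a 2.9-fold higher number from compound 1 to compound 3 (0.46 log units; beyond the scatter) is the closest reference, since compounds 1 and 3 differ only in how methyl and fluorine are arranged on the same kind of unsaturated chain, and it was modest. The step of a 12-fold higher number from compound 1 to compound 2 (1.08 log units; beyond the scatter) was large, but it exchanges the whole chain for a ring and so speaks less to the present change. For the measured compounds named here, a fluorine-free chain has no precedent here, so a modest shift in either direction in this assay is the expectation, with the present values not favouring one side strongly. Compound 4 is therefore estimated at 120 nM, in the range 40 nM to 360 nM, which corresponds to an expected step of a 1.5-fold higher number from compound 3 to compound 4 (0.18 log units; within the scatter).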

Compound 4, half-maximal inhibitory concentration: 28 nM
The estimate for compound 4 lay 4.3-fold (0.63 log units) above the measured number, outside the stated range (below it).
By their numbers in this assay, from the lowest: compounds 1 and 4 (each within the scatter of the next); then compound 3; then compound 2.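

Loss of the fluorine at this position gives a clear gain in this assay (a 2.9-fold lower number from compound 3 to compound 4 (0.46 log units; beyond the scatter)), so the higher number of compound 3 cannot be attributed to the unsaturated chain as such. The fluorine-free chain also sits level with the fluorinated chain of compound 1 (no change at the digits printed from compound 1 to compound 4 (within the scatter)), which shows that fluorine is not needed for a number of this size, although its effect within these chains depends on how it and the methyl are arranged. The open unsaturated chain of compound 4 also keeps a large margin over the 4-(aminomethyl)cyclohexyl group of compound 2 (a 12-fold lower number from compound 2 to compound 4 (1.08 log units; beyond the scatter)), so that margin does not depend on fluorine. No measurement at hand gives a cause for any of these steps.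

Going by these compounds, whether the penalty seen in compound 3 is particular to fluorine remains open, and chlorine in its place on the chain would test that. Also unsettled is how the saturated counterpart of the chain, or a longer chain ending in the same amine, would compare with compound 4.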